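A chloro group added to compound 1

The source may hold more compounds than are shown below. What is called first, only, known or untested is meant among the compounds shown, and "the series" means these compounds.

Compound 1 `COc1cc(OC)c(Cl)c(-c2ccc3c(NC(=O)c4ccc(N5CCN(C)CC5)cc4)n[nH]c3n2)c1Cl`: 1.7 nM
Compound 2 `COc1cc(OC)c(Cl)c(-c2ccc3c(NC(=O)c4ccc(N5CCCN(C)CC5)cc4)n[nH]c3n2)c1Cl`: 1.3 nM
Compound 3 `COc1cc(OC)c(Cl)c(-c2ccc3c(NC(=O)c4ccc(N5CCN(C(C)=O)CC5)cc4)n[nH]c3n2)c1Cl`: 43.3 nM

In a functional assay on NCI-H1581 cells (Homo sapiens) for antiproliferative activity, read by CCK-8 assay, with a stated time of 72 h (on this read-out lower numbers stand for stronger inhibition and higher numbers for weaker inhibition), compound 1 gives 1.7 nM. Its nearest neighbour among the three numbers is reached by a 1.3-fold lower number from compound 1 to compound 2 (0.12 log units; within the scatter). Its furthest is reached by a 25-fold higher number from compound 1 to compound 3 (1.41 log units; beyond the scatter). The number of compound 1 therefore sits with that of compound 2, well apart from that of compound 3.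

Compound 4 `COc1cc(OC)c(Cl)c(-c2ccc3c(NC(=O)c4ccc(N5CCN(C)CC5)c(Cl)c4)n[nH]c3n2)c1Cl` has not yet been measured. It differs from compound 1 by chloro in place of hydrogen on an aromatic carbon, a chloro in place of hydrogen on an aromatic carbon, ortho to a 4-methylpiperazin-1-yl group.

For the measured compounds named here, no measured step adds anything to that aromatic ring. All of them alter the 4-methylpiperazin-1-yl group itself, so they bear on the question only indirectly. The change to compound 2 shows a small step, a 1.3-fold lower number from compound 1 to compound 2 (0.12 log units; within the scatter), whereas the change to compound 3 shows a large one, a 33-fold higher number from compound 2 to compound 3 (1.52 log units; beyond the scatter). Neither gives a direct precedent, so only a modest rise in the number is expected in this assay, and a step within the scatter would be no surprise. The expected step is a 1.8-fold higher number from compound 1 to compound 4 (0.25 log units; within the scatter). Compound 4 is estimated at 3 nM, with an expected range from 1 nM to 12 nM.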

Compound 4, half-maximal inhibitory concentration: 191 nM
For compound 4 the middle estimate is 64-fold (1.80 log units) below the measured one, and the stated range ends below it.
By their numbers in this assay, from the lowest: compounds 2 and 1 (each within the scatter of the next); then compound 3; then compound 4.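

In this assay, for the compounds shown here, a single chloro on the aromatic carbon ortho to a 4-methylpiperazin-1-yl group carries a far larger penalty than the earlier compounds could suggest, with a 110-fold higher number from compound 1 to compound 4 (2.05 log units; beyond the scatter). This ring position, the same in compounds 1, 2 and 3, therefore matters a great deal: one added heavy atom, with no hydrogen-bond donor or acceptor and no net charge, moves the number further than the change from methyl to acetyl on the ring nitrogen that leaves compound 3 at 43.3 nM. Nothing measured here bears on the cause of this loss of activity.

The compounds shown leave open whether the loss belongs to chloro in particular or would follow any group on this carbon, and a fluoro, methyl or methoxy group there would separate those readings. They also leave open whether chloro at this place would weigh as heavily alongside the 4-methyl-1,4-diazepan-1-yl group of compound 2, or whether the same carbon behaves differently with a different amine attached to the ring.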